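The source may report more compounds than this note shows. Statements on the series, on what has been measured and on what is new or still open speak of the compounds shown alone.

Three esters of the shared core have been run in an assay for inhibition of beta-glucuronidase (Bos taurus), read by spectrophotometry, with a stated time of 30 min; on this read-out higher numbers stand for weaker inhibition and lower numbers for stronger inhibition: compound 1, `COc1ccc(/C=C/C(=O)OCCn2c([N+](=O)[O-])cnc2C)cc1`; compound 2, `Cc1ncc([N+](=O)[O-])n1CCOC(=O)c1cccc(Cl)c1`; and compound 3, `Cc1ncc([N+](=O)[O-])n1CCOC(=O)c1cccc(F)c1`. Compound 1 gives 31100 nM, compound 2 gives 16300 nM and compound 3 gives 8100 nM. Compound 2 stands second highest of the three numbers; its nearest neighbour is compound 1 and its furthest is compound 3, and both gaps lie within the scatter. The next step leads to compound 4, `Cc1ncc([N+](=O)[O-])n1CCOC(=O)c1cccnc1`, by pyridin-3-yl in place of 3-chlorophenyl on a carbonyl carbon. Within the data shown here, the only measured step touching the aromatic ester portion is a 2.0-fold lower number from compound 2 to compound 3 (0.30 log units; within the scatter), which was within the scatter. Among the measured compounds shown here, no measured step covers a ring nitrogen in place of a ring substituent, so no step beyond the scatter is expected in this assay. Compound 4 is therefore estimated at 16000 nM, between 5000 nM and 50000 nM, the expected step being a 1.0-fold lower number from compound 2 to compound 4 (0.01 log units; within the scatter).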

Compound 4, half-maximal inhibitory concentration: 32600 nM
Compound 4: middle estimate off by 2.0-fold (0.31 log units), on the low side, within the range that was stated.
By their numbers in this assay, from the lowest: compounds 3, 2, 1 and 4 (each within the scatter of the next, the first and the last beyond it).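

In this assay, among these compounds, pyridin-3-yl on the carbonyl carbon gives a 2.0-fold higher number from compound 2 to compound 4 (0.30 log units; within the scatter) and a 4.0-fold higher number from compound 3 to compound 4 (0.60 log units; beyond the scatter) and thus produces the first step at this position to clear the scatter, though only against the 3-fluorophenyl ester. A ring nitrogen therefore separates from the fluoro compound but not from the chloro compound. No measured evidence here bears on the reason for this step. Open, as far as these compounds go, is how pyridin-4-yl would compare on the same carbonyl carbon. Also open, from the compounds shown here alone, is whether a phenyl ring carrying an amine or a carboxylic acid would read closer to compound 3 or compound 4.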